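Cytotoxicity on Vero cells: swapping the indolyl group

A few compounds are considered here, and "the series" means these few. Any claim that something is new, unique, unknown or untested is made for them only; others in the source may bear on it.

The compounds measured so far:
compound 1 `COc1ccc(/C(Cl)=C/C=C(\C#N)C(=O)c2c(C)[nH]c3ccccc23)cc1OC`, 65900 nM;
compound 2 `Cc1[nH]c2ccccc2c1C(=O)/C(C#N)=C/C=C(\Cl)c1ccc(Br)cc1`, "not determined" (no result reported);
compound 3 `COc1cc(/C(Cl)=C/C=C(\C#N)C(=O)c2c(C)[nH]c3ccccc23)cc(OC)c1OC`, 68300 nM.

Going by the values given here, in an ADME assay on Vero cells (Chlorocebus sabaeus) for cytotoxicity, read by sulforhodamine B assay, with a stated time of 48 h (a higher number here means that more compound is tolerated, a lower number that less compound is tolerated), compound 3 stands together with compound 1, the only other compound with a number, and the step of a 1.0-fold higher number from compound 1 to compound 3 (0.02 log units; within the scatter) lies within the scatter. Compound 4 `COc1cc(/C(Cl)=C/C=C(\C#N)C(=O)c2c[nH]c3ccc(Br)cc23)cc(OC)c1OC` differs from compound 3 by 5-bromo-1H-indol-3-yl in place of 2-methyl-1H-indol-3-yl on a carbonyl carbon. Among the compounds with values here, no measured step touches the part of compound 3 that changes here, so there is nothing in the numbers that points in either direction. Compound 4 is therefore expected to give a number close to that of compound 3, with an expected step of a 1.1-fold lower number from compound 3 to compound 4 (0.06 log units; within the scatter), no larger than the scatter. The estimate for compound 4 is 60000 nM, between 25000 nM and 140000 nM.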

Compound 4, concentration lethal to 50% of the cells: 41500 nM
The estimate for compound 4 lay 1.4-fold (0.16 log units) above the measured number; low and high end bracket the measured number.
By their numbers in this assay, from the lowest: compounds 4, 1 and 3 (each within the scatter of the next).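

Going by these compounds alone, at the carbonyl carbon, which no earlier step had touched, this assay gives a 1.6-fold lower number from compound 3 to compound 4 (0.22 log units; within the scatter) for 5-bromo-1H-indol-3-yl in place of 2-methyl-1H-indol-3-yl. This exchange of indolyl groups therefore stays within the scatter, and tolerance on these cells does not separate the two compounds. No measurement at hand bears on the reason for this result. Going by these compounds, because the methyl group leaves and the bromine enters in one step, the share of each stays open. Also open, on these data alone, is whether an indol-3-yl group carrying an amine or a carboxylic acid would stay within the scatter.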